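The compounds below may be only part of what the source reports. "The series", "measured", "known", "first", "only" and "open" are said of these compounds alone.

Measured compounds in an assay on microsomes for inhibition of acyl-CoA:cholesterol acyltransferase (Oryctolagus cuniculus); a lower number here means a stronger inhibitor, a higher number a weaker inhibitor:
- compound 1 `CC(C)c1ccc(C2(CNC(=O)Nc3c(C(C)C)cccc3C(C)C)CCCC2)cc1` gives 48 nM
- compound 2 `CC(C)c1cccc(C(C)C)c1NC(=O)NCC1(c2ccc(CC(C)(C)C)cc2)CCCC1` gives 159 nM
- compound 3 `CC(C)c1cccc(C(C)C)c1NC(=O)NCC1(c2ccc([N+](=O)[O-])cc2)CCCC1` gives 131 nM

Compound 3 holds the second highest of the three numbers. Its nearest neighbour is compound 2: a 1.2-fold lower number from compound 2 to compound 3 (0.08 log units; within the scatter), within the scatter. The furthest is compound 1: a 2.7-fold higher number from compound 1 to compound 3 (0.44 log units; beyond the scatter), beyond the scatter.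

Compound 4 `CC(C)c1cccc(C(C)C)c1NC(=O)NCC1(c2cccc(N(C)C)c2)CCCC1` differs from compound 3 in one place: 3-(dimethylamino)phenyl in place of 4-nitrophenyl on a saturated ring carbon. The measured steps that bear on it are those changing the group on the same saturated ring carbon. a 2.7-fold higher number from compound 1 to compound 3 (0.44 log units; beyond the scatter) and a 3.3-fold higher number from compound 1 to compound 2 (0.52 log units; beyond the scatter) show that putting nitro or neopentyl in place of isopropyl there raises the number modestly, while a 1.2-fold lower number from compound 2 to compound 3 (0.08 log units; within the scatter) shows nitro and neopentyl giving numbers within the scatter of each other. Going by the values given here, no measured step introduces a 3-(dimethylamino)phenyl group, so the direction of this change cannot be read from the data. Since all three measured values sit within a modest span, compound 4 is expected to remain close to compound 3, a 1.1-fold lower number from compound 3 to compound 4 (0.04 log units; within the scatter), within the scatter. Compound 4 is estimated at 120 nM, with a range from 45 nM to 320 nM.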

Compound 4, half-maximal inhibitory concentration: 33 nM
For compound 4 the middle estimate is 3.6-fold (0.56 log units) above the measured one; measured number below the stated range.
By their numbers in this assay, from the lowest: compounds 4 and 1 (each within the scatter of the next); then compounds 3 and 2 (each within the scatter of the next).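

In this assay, 3-(dimethylamino)phenyl on the saturated ring carbon gives a 4.0-fold lower number from compound 3 to compound 4 (0.60 log units; beyond the scatter) and also a 4.8-fold lower number from compound 2 to compound 4 (0.68 log units; beyond the scatter), so the three replacements of 4-isopropylphenyl shown here do not all shift the number the same way. Set against 4-isopropylphenyl itself, the same group gives a 1.5-fold lower number from compound 1 to compound 4 (0.16 log units; within the scatter), which is the first replacement shown that stays within the scatter, whereas the nitro and neopentyl groups raised the number beyond it. No measurement on hand accounts for these differences.

The step to 3-(dimethylamino)phenyl changes both the substituent and its ring position at once, so neither can be credited on its own. On these data alone, whether 4-(dimethylamino)phenyl would track compound 4 or compound 3, and where 3-nitrophenyl or 3-isopropylphenyl would fall, remains open.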